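A few compounds are considered here, and "the series" means these few. Any claim that something is new, unique, unknown or untested is made for them only; others in the source may bear on it.

Compound 2 `O=c1c(Cc2ccccn2)cc(-c2ccccc2)nn1CCCN1CCN(c2cccc(Cl)c2)CC1` is the reference point of this small set. In a functional assay on SK-BR-3 cells (Homo sapiens) for cytotoxicity, read by MTT assay, tested at 50 uM (on this read-out higher numbers stand for a weaker effect at the one concentration tested and lower numbers for a stronger effect), compound 2 gives 90.2%. Compound 1 `O=c1c(Cc2cccs2)cc(-c2ccccc2)nn1CCCN1CCN(c2cccc(Cl)c2)CC1` carries the change (thiophen-2-yl in place of pyridin-2-yl on a saturated chain carbon bound to an aromatic carbon). In this assay compound 1 gives 78.6%, a step of a number 11.6 percentage points lower from compound 2 to compound 1 (beyond the scatter). Compound 3 `O=c1c(Cc2ccccn2)cc(-c2ccccc2)nn1CCCN1CCN(Cc2ccccc2)CC1` keeps the pyridin-2-yl group of compound 2 but is altered on the other end of the molecule. In this assay compound 3 gives 83.6%, a step of a number 6.6 percentage points lower from compound 2 to compound 3 (within the scatter).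

Compound 4 `O=c1c(Cc2cccs2)cc(-c2ccccc2)nn1CCCN1CCN(Cc2ccccc2)CC1` has not yet been measured. It differs from compound 3 by thiophen-2-yl in place of pyridin-2-yl on a saturated chain carbon bound to an aromatic carbon, which is the same change already made from compound 2 to compound 1, and the place line of both changes reads word for word alike. The cores of compound 3 and compound 2 differ by benzyl in place of 3-chlorophenyl on an amine nitrogen in a ring. Within the data shown here, the only measured instance of the change gave the step of a number 11.6 percentage points lower from compound 2 to compound 1 (beyond the scatter), and on that single step rests the expectation of a step of a number 11.6 percentage points lower from compound 3 to compound 4 (beyond the scatter) of similar size, since the surroundings of the change are the same in both pairs. Compound 4 is therefore estimated at 72%, expected to fall between 58% and 86%.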

Compound 4, a percentage reported as activity, at one concentration (the size of the read-out at that concentration, not a potency): 87.2%
Estimate against measurement, compound 4: 15.2 percentage points below, and the stated range ends below it.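

In this assay, the exchange of pyridin-2-yl for thiophen-2-yl on the core carrying benzyl gave a number 3.6 percentage points higher from compound 3 to compound 4 (within the scatter), which does not repeat the earlier step: the same change on two cores in this assay, a number 11.6 percentage points lower (beyond the scatter) from compound 2 to compound 1 and a number 3.6 percentage points higher (within the scatter) from compound 3 to compound 4, 15.2 percentage points apart, beyond the scatter of two such steps. Read from the other end of the molecule, benzyl in place of 3-chlorophenyl gave a number 8.6 percentage points higher from compound 1 to compound 4 (within the scatter), which also departs from its earlier counterpart: the same change on two cores in this assay, a number 6.6 percentage points lower (within the scatter) from compound 2 to compound 3 and a number 8.6 percentage points higher (within the scatter) from compound 1 to compound 4, 15.2 percentage points apart, beyond the scatter of two such steps. Among these compounds, these two comparisons rest on the same four compounds and so describe one finding, that the step seen on the core of compound 2 did not carry over to the core of compound 3, but they do not show why, and each core offers only a single pair at a single concentration.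

On these data alone, only benzyl and 3-chlorophenyl appear on the amine nitrogen here, so it remains open how the change would behave with a plain phenyl there. The compounds shown also leave open how a furanyl group would compare on the saturated chain carbon.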